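The source may hold more compounds than are shown below. What is called first, only, known or untested is meant among the compounds shown, and "the series" means these compounds.

In a functional assay on CHO-RD-HGA16 cells for agonist activity at Orexin/Hypocretin receptor type 1 (Homo sapiens), read by fluorescence and calcium flux, with a stated time of 30 min (on this read-out higher numbers stand for an effect only at larger amounts of compound and lower numbers for an effect already at smaller amounts), compound 2 `COc1ccc(-c2cc(C(=O)N(C)C)ccn2)cc1S(=O)(=O)Nc1cccc(NCCNC(=O)c2cccc(C)c2)c1` gives 1810 nM. Among the two values shown so far, this is the only true number. Compound 1 `COc1ccc(-c2cccc(C(=O)N(C)C)c2)cc1S(=O)(=O)Nc1cccc(N2CCN(C(=O)c3cccc(C)c3)CC2)c1` gives only > 10000 nM in this assay, which is a limit of the assay rather than a number; (the limit of > 10000 nM in this assay, at which 1 of the 2 values shown sits). Compound 3 `COc1ccc(-c2ccnc(C(=O)N(C)C)c2)cc1S(=O)(=O)Nc1cccc(NCCNC(=O)c2cccc(C)c2)c1` has not yet been measured in this assay. It differs from compound 2 in a single place: 2-(dimethylcarbamoyl)pyridin-4-yl in place of 4-(dimethylcarbamoyl)pyridin-2-yl on an aromatic carbon. The two compounds are built from the same atoms, joined differently, so the change is a rearrangement within the pyridine ring and its attached dimethylcarbamoyl group rather than an addition or removal. Among the measured compounds shown here, no step between two measured compounds is available here, so the size of this kind of change cannot be read from a measured pair. The expected step of a 1.4-fold higher number from compound 2 to compound 3 (0.14 log units; within the scatter) is therefore small, a slight loss that may well stay within the usual scatter. For compound 3 the estimate in this assay is 2500 nM, with a range from 600 nM to 10000 nM.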

Compound 3, half-maximal effective concentration: 5170 nM
The estimate for compound 3 lay 2.1-fold (0.32 log units) below the measured number; the measured number falls inside the stated range.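

Among the compounds shown here, the pair gives the first measured step: in this assay, exchanging 4-(dimethylcarbamoyl)pyridin-2-yl for 2-(dimethylcarbamoyl)pyridin-4-yl brings a 2.9-fold higher number from compound 2 to compound 3 (0.46 log units; beyond the scatter), a modest change but one beyond the usual scatter. The two groups have the same atoms and the same counts of hydrogen-bond donors and acceptors, so what separates the two compounds is how this group is joined, not what it is made of, and this aromatic carbon, para to a methoxy group, is therefore sensitive to such a rearrangement even without any atom being added or removed. Nothing measured here gives a reason for this step.

The compounds shown leave open whether the dimethylcarbamoyl group itself is needed on the pyridine ring, as neither a carboxylic acid nor a simple amine appears in its place in either arrangement. Also open, as far as these compounds go, is how a third arrangement of the same atoms on the pyridine ring would compare with compound 2 at 1810 nM and with compound 3 at 5170 nM.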